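A hydroxy-for-methoxy change repeated on a fluorinated analogue

The source may hold more compounds than are shown below. What is called first, only, known or untested is meant among the compounds shown, and "the series" means these compounds.

Compound 1, `O=C(/C=C/c1coc2cc(O)ccc2c1=O)NCc1ccccc1`, gives 4690 nM in a functional assay on Huh-7 cells (Homo sapiens) for inhibition, read by MTT assay, with a stated time of 48 h; on this read-out higher numbers stand for weaker inhibition and lower numbers for stronger inhibition.
Compound 2, `COc1ccc2c(=O)c(/C=C/C(=O)NCc3ccccc3)coc2c1`, gives 13600 nM in this assay.
Compound 3, `COc1ccc2c(=O)c(/C=C/C(=O)NCc3ccc(F)cc3)coc2c1`, gives 21000 nM in this assay.

The three measured compounds share one core and differ at two places. Compound 2 and compound 3 differ by fluoro in place of hydrogen on an aromatic carbon; this gave a 1.5-fold higher number from compound 2 to compound 3 (0.19 log units; within the scatter), so the two values cannot be told apart. Compound 2 and compound 1 differ by hydrogen in place of methyl on an oxygen on an aromatic ring, which gave a 2.9-fold lower number from compound 2 to compound 1 (0.46 log units; beyond the scatter). Compound 3 holds the highest of the three numbers, but only its gap to compound 1 lies beyond the scatter.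

The unmeasured compound 4, `O=C(/C=C/c1coc2cc(O)ccc2c1=O)NCc1ccc(F)cc1`, differs from compound 3 by hydrogen in place of methyl on an oxygen on an aromatic ring. The place of this change is described in the same words as for the change from compound 2 to compound 1, so it is the same change, made once more on the fluorinated analogue. Among the measured compounds shown here, only one measured instance of it exists, so the expectation rests on that alone.

Compound 4 is expected to come in near 7200 nM in this assay. The likely spread for compound 4 is estimated to run from 3500 nM to 15000 nM. For the measured compounds named here, for compound 4 the expected step is a 2.9-fold lower number from compound 3 to compound 4 (0.46 log units; beyond the scatter), which rests on the measured 2.9-fold lower number from compound 2 to compound 1 (0.46 log units; beyond the scatter) as the sole precedent for this change.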

Compound 4, half-maximal inhibitory concentration: > 100000 nM
Compound 4 ended at the assay's limit (the forecaster's own chance of this, stated with the estimate: 5%); middle value at least 13-fold (1.14 log units) from the limit.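

In this assay compound 4 gives > 100000 nM, which is a limit of the assay and not a number: the limit of > 100000 nM in this assay, at which 1 of the 4 values shown sits. Even so, the change from methoxy to hydroxy did not carry over from one core to the other, since it gave an at least 4.7-fold higher number from compound 3 to compound 4 (0.67 log units; beyond the scatter), opposite in direction to the earlier step: the same change on two cores in this assay, a 2.9-fold lower number (0.46 log units; beyond the scatter) from compound 2 to compound 1 and an at least 4.7-fold higher number (0.67 log units; beyond the scatter) from compound 3 to compound 4, at least 13-fold (1.14 log units) apart, beyond the scatter of two such steps. Among the compounds shown here, the fluoro-for-hydrogen change did not carry over either, giving an at least 21-fold higher number from compound 1 to compound 4 (1.32 log units; beyond the scatter), but these results rest on the single compound 4 at a limit, so they show that neither step could be transferred between these cores, not why this happened or how large the true steps are: the same change on two cores in this assay, a 1.5-fold higher number (0.19 log units; within the scatter) from compound 2 to compound 3 and an at least 21-fold higher number (1.32 log units; beyond the scatter) from compound 1 to compound 4, at least 13-fold (1.14 log units) apart, beyond the scatter of two such steps.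

The compounds shown leave open whether the break in the pattern belongs only to the pairing of hydroxy with fluoro, or whether a chloro or a methyl in place of the fluoro would also give a result like that of compound 4. They also leave open whether an amine in place of the hydroxy would follow compound 1 or compound 4, and how far past the limit compound 4 truly lies.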